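Piperidine nitrogen substituent and maximal response in the series

The source may report more compounds than this note shows. Statements on the series, on what has been measured and on what is new or still open speak of the compounds shown alone.

Three compounds have been run in a functional assay on CHO cells for agonist activity at 5-hydroxytryptamine receptor 4 (Homo sapiens), read by a luciferase reporter and cAMP accumulation, with a stated time of 4 h; on this read-out higher numbers stand for larger maximal responses and lower numbers for smaller maximal responses. Compound 1 `CC(C)c1nc(C(=O)NCC2CCN(C3CCOCC3)CC2)c2ccccn12` gives 29%, compound 2 `CC(C)c1nc(-c2nnc(C3CCN(C4CCC4)CC3)o2)c2ccccn12` gives 55%, and compound 3 `CCN1CCC(NC(=O)c2nc(C(C)C)n3ccccc23)CC1` gives 100%. Compound 3 therefore stands highest of the three numbers; its nearest neighbour is compound 2, whose number lies beyond the scatter below it, and compound 1 lies further below, also beyond the scatter. For the measured compounds named here, no pair among the measured compounds differs in one place only, so these gaps are read as what the values show and not as single-point steps.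

Compound 4 `CC(C)c1nc(C(=O)NC2CCN(CC3CCOC3)CC2)c2ccccn12` has not yet been measured. It differs from compound 3 by oxolan-3-yl in place of methyl on a saturated chain carbon bound to an amine nitrogen in a ring. Within this set, the compound carrying a ring on the amine nitrogen side of the chain, compound 1 with 29%, sits far below compound 3 with 100%, though compound 1 also differs from compound 3 elsewhere, so this is a loose pointer only. Given that pointer, a downward step is expected in this assay, of moderate size, as a number 30 percentage points lower from compound 3 to compound 4 (beyond the scatter). Compound 4 is thus estimated at 70%, with a range from 40% to 100%.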

Compound 4, largest response reached (Emax), in percent of the reference or control that the assay uses: 81%
The estimate for compound 4 lay 11 percentage points below the measured number, within the range that was stated.
By their numbers in this assay, from the lowest: compound 1; then compound 2; then compound 4; then compound 3.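

Oxolan-3-yl in place of methyl on a saturated chain carbon bound to an amine nitrogen in a ring gives the only single-place step in the series so far in this assay: a number 19 percentage points lower from compound 3 to compound 4 (beyond the scatter). The step is modest, and this place in the structure accepts the ring-bearing group without losing the maximal response, with compound 4 still at 81%. No measurement at hand speaks to why the step has this size.

The compounds shown do not separate the contributions of the ring, its oxygen and the extra chain atoms: a cyclopentylmethyl group or a longer plain alkyl chain such as butyl in the same place would tell these apart. As far as these compounds go, whether the change from ethyl to (oxolan-3-yl)methyl gives a step of similar size on the core of compound 1 or of compound 2 also remains open.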